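A few compounds are considered here, and "the series" means these few. Any claim that something is new, unique, unknown or untested is made for them only; others in the source may bear on it.

Measured compounds:
compound 1, `COc1ccc(Br)cc1CCc1c(F)cccc1C(=O)/N=C(\N)NCCC1CCCCC1` — "not determined" (no result reported)
compound 2, `COc1ccc(Br)cc1CCc1c(F)cccc1C(=O)/N=C(\N)NCCCCN(C)Cc1ccccc1` — 180 nM

The series rests on a shared core, and only compound 2 carries a number. Compound 1 was tested in a functional assay for antagonist activity at Melanocortin receptor 4 (Homo sapiens), read by cAMP accumulation (on this read-out higher numbers stand for weaker inhibition and lower numbers for stronger inhibition), but no single value was reported for it, so nothing can be said of how it compares. In this assay compound 2 gives 180 nM, and this is the only figure available; it stands alone, with no companion to set it above or below.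

Compound 3, `COc1ccc(Br)cc1CCc1c(F)cccc1C(=O)/N=C(\N)NCC1CCNCC1`, has not yet been measured. It differs from compound 2 by piperidin-4-yl in place of 3-(benzyl(methyl)amino)propyl on a saturated chain carbon bound to an amine nitrogen. Within the data shown here, no pair of measured compounds shows a step of this kind, so there is no earlier change to lean on. A group of this size leaving and a smaller ring entering, with a new hydrogen-bond donor, is a change large enough that a shift beyond the usual scatter would not be surprising, and the direction he expects is toward weaker inhibition, though a result within the scatter cannot be ruled out.

Compound 3 is therefore expected to give roughly 600 nM, with a range from 150 nM to 2500 nM, which would mean an expected step of a 3.3-fold higher number from compound 2 to compound 3 (0.52 log units; beyond the scatter).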

Compound 3, half-maximal inhibitory concentration: 31 nM
Estimate against measurement, compound 3: 19-fold (1.29 log units) above; the measured number lies below the stated range.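

In this assay, putting piperidin-4-yl in place of 3-(benzyl(methyl)amino)propyl on a saturated chain carbon bound to an amine nitrogen gives a 5.8-fold lower number from compound 2 to compound 3 (0.76 log units; beyond the scatter). Among these compounds, this is the first step that can be read, and it shows that, for this pair, the leaving group's 12 heavy atoms and aromatic ring are not required for inhibition: the 6 heavy atoms of piperidin-4-yl give a lower number, by a margin beyond the scatter. Nothing available here bears on what lies behind this shift.

This single step swaps the size of the group, its aromatic ring for a non-aromatic one and the hydrogen-bond donor count all at once, so it cannot show which of these differences carries the shift, and compound 1, without a number, adds no second comparison. It also leaves open whether a methyl group on the piperidine nitrogen, a pyrrolidine ring or an open chain ending in a primary amine would give a number close to that of compound 3.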